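The compounds below may be only part of what the source reports. "The series", "measured", "known", "first", "only" and "open" are said of these compounds alone.

Compound 1 `CC(C)=CCC1Cc2c(O)cc(=O)n(CCCO)c2CC1(C)C` and compound 2 `CC(C)=CCC/C(C)=C/CC1Cc2c(O)cc(=O)n(CCCO)c2CC1(C)C` share one core and are both without measurable effect in a functional assay on PANC-1 cells (Homo sapiens) for inhibition, read by MTT assay, with a stated time of 24 h, tested at 10 uM (a higher number here means more inhibition at the concentration tested (going by the name of the read-out), a lower number less inhibition), at the concentration tested. In this assay compound 1 gives 0%, and compound 2 gives 0%. The only measured step, no change at the digits printed from compound 1 to compound 2 (within the scatter), is flat, so compound 1 stands level with compound 2 at the digits shown and nothing within this pair separates them. Compound 3 `CCOc1cc(=O)n(CCCO)c2c1CC(CC=C(C)C)C(C)(C)C2` has not yet been measured. It differs from compound 1 by ethyl in place of hydrogen on an oxygen on an aromatic ring, that is, hydroxy becomes ethoxy. Going by the values given here, no measured step touches this oxygen; the single known step, no change at the digits printed from compound 1 to compound 2 (within the scatter), concerns a different kind of change and produced no movement, so it bears on compound 3 only as a sign that changes to this core have so far left the read-out unmoved. With both measured compounds at the bottom of the scale, the expected step of a number 5 percentage points higher from compound 1 to compound 3 (within the scatter) is none beyond the scatter. Compound 3 is therefore estimated to give 5%, within a range from 0% to 25%.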

Compound 3, a percentage reported as inhibition, at one concentration (the size of the read-out at that concentration, not a potency): 16.6%
Compound 3: middle estimate off by 11.6 percentage points, on the low side; the range from low to high includes it.
By their numbers in this assay, from the lowest: compounds 1 and 2 (each within the scatter of the next); then compound 3.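

In this assay, hydroxy to ethoxy, with ethyl in place of hydrogen on an oxygen on an aromatic ring, is the first change shown to move the read-out: a number 16.6 percentage points higher from compound 1 to compound 3 (beyond the scatter). The earlier step, no change at the digits printed from compound 1 to compound 2 (within the scatter), lay elsewhere on the shared core and stayed flat, so only this result shows that the group on this oxygen can alter the read-out and that a free hydroxy here is not needed for a measurable effect, although the step is modest and compound 3 reaches only 16.6% at a single concentration. No measured evidence accounts for this step.

A single group on this oxygen cannot show whether the effect tracks the size or the nature of the group, and a methyl, a butyl chain, a benzyl or a chain ending in a carboxylic acid could each move the read-out differently from ethyl. On these data alone, it also remains open whether ethoxy would give a similar step on the core of compound 2, with its longer side chain.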